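The source may hold more compounds than are shown below. What is called first, only, known or untested is meant among the compounds shown, and "the series" means these compounds.

Compound 1 `Fc1cc(Cl)ccc1-c1ccc(Cn2nnc3c(F)cccc32)cn1` was examined in an ADME assay on microsomes from liver (Homo sapiens) for metabolic stability, tested at 2.5 uM (a higher number here means faster removal of the compound, a lower number slower removal), where compound 1 gives 0.1 mL/min/g. A second compound, compound 2 `Fc1ccc2nnn(Cc3ccc(-c4ccc(Cl)cc4F)nc3)c2c1`, was run in the same test, and in this assay compound 2 gives 0.1 mL/min/g. On these numbers compound 1 stands level with compound 2: the two readings sit within the usual scatter of each other, so nothing separates them, and both point to slow removal of the compound.

The step from compound 1 leads to compound 3 `Fc1cc(Cl)ccc1-c1ccc(Cn2nnc3c(Br)cccc32)cn1`, which has not yet been measured in this assay. The change is bromo in place of fluoro on an aromatic carbon. Among the measured compounds shown here, no measured pair in this set shares this kind of change, so there is no measured step to lean on. Given that compound 1 gives 0.1 mL/min/g in this assay, the expectation is that compound 3 moves little, with an estimated step of a 1.5-fold higher number from compound 1 to compound 3 (0.18 log units; within the scatter) that need not go beyond the scatter. The estimate for compound 3 in this assay is 0.15 mL/min/g, with a likely range from 0.05 mL/min/g to 0.5 mL/min/g.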

Compound 3, intrinsic clearance in a liver preparation (reported as CLH), per the amount of preparation that the assay uses: 0.1 mL/min/g
Beside the measured number, compound 3's estimate is 1.5-fold (0.18 log units) above it, within the range that was stated.
By their numbers in this assay, from the lowest: compounds 1, 2 and 3 (each within the scatter of the next).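

Among the compounds shown here, with bromo in place of fluoro on an aromatic carbon of the six-membered aromatic ring of carbon only, this assay shows no change at the digits printed from compound 1 to compound 3 (within the scatter), the first step in this set that can be read at a single place. Compounds 1 and 2 gave no such reading, so this position now has a measured result for two halogens, and removal stays slow with either of them on the shared core. Nothing measured here bears on the reason for this result.

On these data alone, all of this concerns only fluoro and bromo, which each add a single heavy atom and no hydrogen-bond donors or acceptors, so it remains open whether a different kind of group on this carbon, such as an amine, a carboxylic acid or a longer chain, would leave the reading where it is. As far as these compounds go, it is also open whether bromo would give the same result at other places on the core, or on a core that differs elsewhere.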